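A few compounds are considered here, and "the series" means these few. Any claim that something is new, unique, unknown or untested is made for them only; others in the source may bear on it.

Measured compounds:
Compound 1 `CC(C)(N)C(=O)N[C@H](COCc1ccc(F)cc1F)c1nnnn1CCOC(=O)NCCCCO` gives 0.42 nM in a functional assay on cells for inhibition of growth hormone secretagogue receptor type 1 (Homo sapiens), read by FLIPR and calcium flux; on this read-out lower numbers stand for an effect already at smaller amounts and higher numbers for an effect only at larger amounts of compound.
Compound 2 `CC(C)(N)C(=O)N[C@H](COCc1ccccc1C#N)c1nnnn1CCOC(=O)NCCCCO` gives 1.26 nM in this assay.

Among the measured compounds shown here, compound 1 stands at the lower of the two numbers; the one change measured from it, a 3.0-fold higher number from compound 1 to compound 2 (0.48 log units; beyond the scatter), trades the 2,4-difluorophenyl for a 2-cyanophenyl and moves the number beyond the scatter, though only modestly.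

Compound 3 `COc1ccccc1COC[C@@H](NC(=O)C(C)(C)N)c1nnnn1CCOC(=O)NCCCCO` has not been measured. It differs from compound 1 by 2-methoxyphenyl in place of 2,4-difluorophenyl on a saturated chain carbon bound to an oxygen on a saturated carbon. For the measured compounds named here, the only measured step that bears on this is the one from compound 1 to compound 2, where a different group was put in the same place; a change of the same kind is expected here, so the number for compound 3 is expected to rise by about a 2.4-fold higher number from compound 1 to compound 3 (0.38 log units; beyond the scatter), with little basis for a larger move. The estimate for compound 3 in this assay is 1 nM, between 0.4 nM and 2.5 nM.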

Compound 3, half-maximal effective concentration: 1.11 nM
Compound 3: the middle estimate sits 1.1-fold (0.05 log units) below what was measured, and the stated range covers the measured number.
By their numbers in this assay, from the lowest: compound 1; then compounds 3 and 2 (each within the scatter of the next).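

A second replacement of the 2,4-difluorophenyl at this place, on a saturated chain carbon bound to an oxygen on a saturated carbon, also moves the number beyond the scatter in this assay (a 2.6-fold higher number from compound 1 to compound 3 (0.42 log units; beyond the scatter)), so the earlier rise no longer rests on a single group. Compound 1 therefore keeps the lowest number of the three, ahead of both the 2-methoxyphenyl and the 2-cyanophenyl. Methoxy in place of cyano on an aromatic carbon gives a 1.1-fold lower number from compound 2 to compound 3 (0.06 log units; within the scatter) and so leaves these two compounds indistinguishable here, although the two groups differ in their atoms.

Nothing measured here explains these numbers. From the compounds shown here alone, it also remains open whether a plain phenyl or a 4-fluorophenyl at this place would stay as low as compound 1 or rise to the level of compound 2 and compound 3.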